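Benzylic piperidine nitrogen substituent in a dopamine transporter series

The source may report more compounds than this note shows. Statements on the series, on what has been measured and on what is new or still open speak of the compounds shown alone.

Measured compounds:
compound 1 `Fc1ccc(C(SCCNC2CCN(Cc3ccc(Cl)cc3)CC2)c2ccc(F)cc2)cc1`, 39.6 nM
compound 2 `O=C(c1ccc(F)cc1)N1CCC(NCCSC(c2ccc(F)cc2)c2ccc(F)cc2)CC1`, 7.04 nM
compound 3 `O=C(c1cc2ccccc2o1)N1CCC(NCCSC(c2ccc(F)cc2)c2ccc(F)cc2)CC1`, 115 nM

In an assay on membranes from striatum (strain Sprague-Dawley) for displacement of a labelled ligand from sodium-dependent dopamine transporter (Rattus norvegicus), read by scintillation counting, with a stated time of 120 min (on this read-out higher numbers stand for weaker inhibition and lower numbers for stronger inhibition), compound 1 sits second highest of the three numbers. Its nearest neighbour is compound 3, reached by a 2.9-fold higher number from compound 1 to compound 3 (0.46 log units; beyond the scatter); the furthest is compound 2, reached by a 5.6-fold lower number from compound 1 to compound 2 (0.75 log units; beyond the scatter). Between the two carbonyl compounds the step of a 16-fold higher number from compound 2 to compound 3 (1.21 log units; beyond the scatter) is the largest in the set.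

Compound 4 `Fc1ccc(C(SCCNC2CCN(Cc3cc4ccccc4[nH]3)CC2)c2ccc(F)cc2)cc1` is unmeasured. It differs from compound 1 by 1H-indol-2-yl in place of 4-chlorophenyl on a saturated chain carbon bound to an amine nitrogen in a ring. Among the compounds with values here, none of the measured steps changes this position in the same way: the steps from compound 1 replace the whole 4-chlorobenzyl with a carbonyl-linked group, and the step from compound 2 to compound 3 swaps a single aromatic ring for a fused bicycle on a carbonyl carbon. Within the data shown here, that last step, a fused bicycle for a single ring, is the only guidance on the direction, and it points to a weaker number in this assay, though on a different linker.

The expected step is therefore a modest move toward higher numbers, a 2.0-fold higher number from compound 1 to compound 4 (0.31 log units; beyond the scatter), with wide uncertainty. Compound 4 is estimated at 80 nM, within the range 25 nM to 250 nM.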

Compound 4, inhibition constant: 179 nM
The estimate for compound 4 lay 2.2-fold (0.35 log units) below the measured number, and the stated range covers the measured number.
By their numbers in this assay, from the lowest: compound 2; then compound 1; then compounds 3 and 4 (each within the scatter of the next).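

With the saturated chain carbon on the ring amine nitrogen kept, 1H-indol-2-yl in place of 4-chlorophenyl gives a weaker number in this assay (a 4.5-fold higher number from compound 1 to compound 4 (0.66 log units; beyond the scatter)), so a fused bicycle for a single ring goes the same way on this linker as on the carbonyl of compounds 2 and 3, though the two bicycles are not the same. The two bicycle compounds cannot be separated in this assay (a 1.6-fold higher number from compound 3 to compound 4 (0.19 log units; within the scatter)), even though (1H-indol-2-yl)methyl and (1-benzofuran-2-yl)carbonyl differ in both ring and linker. The step to compound 4 from the lowest number in the set is the widest gap so far (a 25-fold higher number from compound 2 to compound 4 (1.41 log units; beyond the scatter)), leaving (4-fluorophenyl)carbonyl as the best of the four groups on this nitrogen.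

The compounds shown do not separate ring from linker, which (1H-indol-2-yl)carbonyl and (1-benzofuran-2-yl)methyl on the same nitrogen would do. They also leave open what the chlorine and the indole hydrogen each contribute, which an unsubstituted benzyl and a 1-methylindol-2-ylmethyl group would address.

No measurement shown here bears on the reason for these steps.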